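Ring contraction on the amine substituent of a kinase series

The compounds below may be only part of what the source reports. "The series", "measured", "known", "first", "only" and "open" are said of these compounds alone.

Measured so far:
compound 1 `CC(C)(C)Oc1ncncc1CNc1cc(N[C@H]2CC[C@@H](O)CC2)c(C#N)cn1` — in an assay on isolated protein for inhibition of protein kinase C theta type (Homo sapiens), read by TR-FRET, with a stated time of 2 h (on this read-out lower numbers stand for stronger inhibition and higher numbers for weaker inhibition), compound 1 gives 200 nM
compound 2 `CC1(C)C[C@H](Nc2nc(NCc3cnccc3C(F)(F)F)ncc2C#N)CC[C@@H]1O` — in this assay compound 2 gives 6 nM

Compound 2 holds the lowest number of the two in this assay; its nearest neighbour, compound 1, sits well beyond the scatter above it, and the two also differ in more than one place, so no single change can be read from that pair.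

Compound 3 `CC1(C)[C@@H](O)C[C@H]1Nc1nc(NCc2cnccc2C(F)(F)F)ncc1C#N` differs from compound 2 in one place: 3-hydroxy-2,2-dimethylcyclobutyl in place of 4-hydroxy-3,3-dimethylcyclohexyl on a nitrogen on an aromatic ring. The hydroxy and dimethyl substitution is kept while the ring shrinks. Among the compounds with values here, no measured pair in this set isolates such a change, so the expectation rests on the change alone. In this assay a moderate loss is expected, the number moving higher, most likely beyond the scatter but with wide uncertainty. The expected step is a 5.0-fold higher number from compound 2 to compound 3 (0.70 log units; beyond the scatter). Compound 3 is estimated at 30 nM, with a range from 8 nM to 150 nM.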

Compound 3, half-maximal inhibitory concentration: 4 nM
Estimate against measurement, compound 3: 7.5-fold (0.88 log units) above; the measured number lies below the stated range.
By their numbers in this assay, from the lowest: compounds 3 and 2 (each within the scatter of the next); then compound 1.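

In this assay, 3-hydroxy-2,2-dimethylcyclobutyl in place of 4-hydroxy-3,3-dimethylcyclohexyl on a nitrogen on an aromatic ring gives a 1.5-fold lower number from compound 2 to compound 3 (0.18 log units; within the scatter). At this position, then, the substituent can carry a four-membered ring of 7 heavy atoms instead of a six-membered ring of 9 heavy atoms, with compound 2 and compound 3 staying level on this read-out. Nothing available here offers an explanation for this tolerance of the smaller ring.

Going by these compounds, the hydroxy group and the two methyl groups are present in both compounds, so what each contributes at this position remains open. A cyclobutyl substituent with an amine or a methoxy group in place of the hydroxy, or one without the two methyl groups, would address that question, as would the other stereoisomers of the ring.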